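Swapping an allyl for a hydroxyethyl on a uracil-type core

A few compounds are considered here, and "the series" means these few. Any claim that something is new, unique, unknown or untested is made for them only; others in the source may bear on it.

Of the compounds shown here, three have been measured in a physicochemical assay for lipophilicity; a lower number here means a more polar compound, a higher number a more lipophilic compound. Compound 1, `C=CCn1c(=O)c(N(C)C)c(C)n(-c2ccccc2)c1=O`, gives 1.98 in this assay. Compound 2, `CCN(CC)c1c(C)n(CC)c(=O)n(-c2ccccc2)c1=O`, shares the same core and gives 2.2, a number that lies within the usual scatter of the value of compound 1. Compound 3, `COc1ccccc1-c1nc(N)nc(N)n1`, is built differently and gives 0.58, well below compound 1, with a gap that is beyond the scatter. Compound 1 therefore sits close to compound 2 and clearly above compound 3.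

Compound 4, `Cc1c(N(C)C)c(=O)n(CCO)c(=O)n1-c1ccccc1`, has not yet been measured. It differs from compound 1 in one place: hydroxymethyl in place of vinyl on a saturated chain carbon bound to an aromatic nitrogen Seen one bond further out, the change reads allyl to 2-hydroxyethyl. For the measured compounds named here, no pair among the measured compounds isolates such a change, so the size of the step can only be estimated.

Because compound 1 stands at 1.98 and the change brings in a group that counts one hydrogen-bond donor and one hydrogen-bond acceptor while removing one double bond, the step is expected to go downward in this assay, beyond the scatter, estimated as a number 1.18 log units lower from compound 1 to compound 4 (beyond the scatter). Compound 4 is expected to give about 0.8, in a range from 0.3 to 1.3.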

Compound 4, partition coefficient: 1.12
Estimate against measurement, compound 4: 0.32 log units below, and the stated range covers the measured number.
By their numbers in this assay, from the lowest: compound 3; then compound 4; then compounds 1 and 2 (each within the scatter of the next).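

For the compounds shown here, the step from allyl to 2-hydroxyethyl is the first single change measured, and it falls on a saturated chain carbon bound to an aromatic nitrogen. In this assay, hydroxymethyl in place of vinyl gives a number 0.86 log units lower from compound 1 to compound 4 (beyond the scatter), which shows that the number at this place is not set by the shared core alone and that a change confined to this chain can move it measurably. No evidence on the cause of this step is available.

The compounds shown do not separate the loss of the double bond from the arrival of the hydroxyl group: a plain propyl chain at this place would isolate the first, while a 2-methoxyethyl chain would keep the oxygen but lack the hydroxyl hydrogen. From the compounds shown here alone, how the number responds to a longer chain such as 3-hydroxypropyl, or to a charged group such as a 2-aminoethyl chain or a carboxylic acid, also remains open, and this single step gives no sign of whether the same change would behave alike on another core.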